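Swapping a pyrrolidine for a triazole on the benzylic arm

The source may report more compounds than this note shows. Statements on the series, on what has been measured and on what is new or still open speak of the compounds shown alone.

Compound 1: `COc1ncc(-c2ccc3nccc(-c4ccc(C)cc4)c3c2)cc1NS(=O)(=O)c1ccc(F)cc1F` — in a functional assay on A549 cells (Homo sapiens) for cytotoxicity, read by MTT assay, with a stated time of 72 h (on this read-out higher numbers stand for weaker inhibition and lower numbers for stronger inhibition), compound 1 gives 1240 nM
Compound 2: `CNCCN(C)Cc1ccc(-c2ccnc3ccc(-c4cnc(OC)c(NS(=O)(=O)c5ccc(F)cc5F)c4)cc23)cc1` — in this assay compound 2 gives 13 nM
Compound 3: `COc1ncc(-c2ccc3nccc(-c4ccc(CN5CCCC5)cc4)c3c2)cc1NS(=O)(=O)c1ccc(F)cc1F` — in this assay compound 3 gives 37.5 nM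

Among these three, compound 3 stands second: the step of a 2.9-fold higher number from compound 2 to compound 3 (0.46 log units; beyond the scatter) is modest, while the step of a 33-fold lower number from compound 1 to compound 3 (1.52 log units; beyond the scatter) is large. The step of a 95-fold lower number from compound 1 to compound 2 (1.98 log units; beyond the scatter) is larger still.

Compound 4, `COc1ncc(-c2ccc3nccc(-c4ccc(Cn5cncn5)cc4)c3c2)cc1NS(=O)(=O)c1ccc(F)cc1F`, differs from compound 3 in one place: 1H-1,2,4-triazol-1-yl in place of pyrrolidin-1-yl on a saturated chain carbon bound to an aromatic carbon. Among the measured compounds shown here, no measured step places a 1H-1,2,4-triazol-1-yl at this position, so the only bearing evidence is what the leaving group contributed. The step of a 33-fold lower number from compound 1 to compound 3 (1.52 log units; beyond the scatter) shows that pyrrolidin-1-yl gave a large gain over hydrogen at this carbon, and the step of a 95-fold lower number from compound 1 to compound 2 (1.98 log units; beyond the scatter) shows a second group doing likewise. With the pyrrolidin-1-yl gone and an untested replacement in its place, part of that gain is expected to be lost, though not all of it; the expected step is an 8.0-fold higher number from compound 3 to compound 4 (0.90 log units; beyond the scatter). Compound 4 is therefore estimated at 300 nM in this assay, within a range of 80 nM to 1200 nM.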

Compound 4, half-maximal inhibitory concentration: 16 nM
Beside the measured number, compound 4's estimate is 19-fold (1.27 log units) above it; measured number outside the range, below it.
By their numbers in this assay, from the lowest: compounds 2 and 4 (each within the scatter of the next); then compound 3; then compound 1.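

At this saturated chain carbon bound to an aromatic carbon, the gain over hydrogen does not depend on pyrrolidin-1-yl: in this assay, 1H-1,2,4-triazol-1-yl gives a 78-fold lower number from compound 1 to compound 4 (1.89 log units; beyond the scatter) and improves on the group it replaces, with a 2.3-fold lower number from compound 3 to compound 4 (0.37 log units; beyond the scatter). Compared with methyl(2-(methylamino)ethyl)amino, the triazole gives a 1.2-fold higher number from compound 2 to compound 4 (0.09 log units; within the scatter), so these two very different groups cannot be told apart here. The position therefore accepts a five-membered aromatic ring with 3 hetero atoms as well as a five-membered non-aromatic ring with 1 hetero atom and an open chain, and all three substituents give a large gain over hydrogen.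

No measurement shown explains this tolerance. As far as these compounds go, it remains open whether a morpholine, a carboxylic acid or a longer chain carrying the triazole would keep the gain.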